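The compounds below may be only part of what the source reports. "The series", "measured", "known", "first", "only" and "open" are said of these compounds alone.

For the measured compounds named here, compound 2 `N#CC1=C(N)Oc2c(N)cc3nc4ccccc4nc3c2C12C(=O)N(Cc1cnnn1-c1ccccc1Br)c1ccccc12` gives 38000 nM in a functional assay on HepG2 cells (Homo sapiens) for antiproliferative activity, read by MTT assay, with a stated time of 48 h (on this read-out higher numbers stand for weaker inhibition and lower numbers for stronger inhibition), and is the only compound here with a number. Compound 1 `N#CC1=C(N)Oc2c(c3nc4ccccc4nc3c3ccccc23)C12C(=O)N(Cc1cnnn1-c1cccc(Br)c1)c1ccccc12` gives > 50000 nM in this assay, which is a limit of the assay rather than a number (the limit of > 50000 nM in this assay, at which 1 of the 2 values shown sits). Compound 3 `Cc1ccc(-n2nncc2CN2C(=O)C3(C(C#N)=C(N)Oc4c(N)cc5nc6ccccc6nc5c43)c3ccccc32)cc1Cl` differs from compound 2 by 3-chloro-4-methylphenyl in place of 2-bromophenyl on an aromatic nitrogen. Going by the values given here, no measured pair shows a change of this kind, so the swap is expected to bring no shift beyond the usual scatter, a 1.1-fold higher number from compound 2 to compound 3 (0.02 log units; within the scatter). Compound 3 is estimated at 40000 nM, within a range from 15000 nM to 100000 nM.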

Compound 3, half-maximal inhibitory concentration: > 50000 nM
Compound 3 gave a limit, no number (the forecaster's own chance of this, stated with the estimate: 40%); middle value at least 1.2-fold (0.09 log units) from the limit.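

For the compounds shown here, putting 3-chloro-4-methylphenyl in place of 2-bromophenyl on the aromatic nitrogen gives the first step that can be read here: an at least 1.3-fold higher number from compound 2 to compound 3 (0.11 log units; that floor lies within the scatter). In this assay, from the compounds shown here alone, compound 3 gives > 50000 nM, which is a limit and not a number, so this change shows no stronger inhibition, and the true size of the step stays unknown. Limits now make up most of this small set: the limit of > 50000 nM in this assay, at which 2 of the 3 values shown sit.

The shown compounds leave open whether any group on this nitrogen gives stronger inhibition. An unsubstituted phenyl, or a carboxylic acid or amine on the phenyl ring, would test this.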